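A few compounds are considered here, and "the series" means these few. Any claim that something is new, unique, unknown or untested is made for them only; others in the source may bear on it.

Compound 1 `COc1ccc(Nc2cc(C)oc(=O)c2)cc1` has been tested in a functional assay on A549 cells (Homo sapiens) for cytotoxicity, read by MTT assay, with a stated time of 72 h; on this read-out higher numbers stand for an effect only at larger amounts of compound and lower numbers for an effect already at smaller amounts. In that assay compound 1 gives only a limit of the assay, > 30 uM, and no number. A second compound, compound 2 `O=c1cc(Nc2ccccc2)cc(-c2ccccc2)o1`, gives 0.12 uM in this assay. The new compound, compound 3 `COc1ccc(Nc2cc(/C=C/c3ccccc3)oc(=O)c2)cc1`, differs from compound 1 by 2-phenylethenyl in place of methyl on an aromatic carbon. Within the data shown here, no measured step covers this change, so any expectation rests on what the values of compound 1 and compound 2 show. Compound 3 is expected to act already at smaller amounts than compound 1, the expected step being an at least 60-fold lower number from compound 1 to compound 3 (1.77 log units; beyond the scatter). The estimate for compound 3 is 0.5 uM, within 0.1 uM to 3 uM.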

Compound 3, concentration for half-maximal effect: 0.11 uM
For compound 3 the middle estimate is 4.5-fold (0.66 log units) above the measured one, and the stated range covers the measured number.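

At this position, next to the ring oxygen, the size of the group clearly matters in this assay: 2-phenylethenyl in place of methyl gives an at least 270-fold lower number from compound 1 to compound 3 (2.43 log units; beyond the scatter). Compound 1 gives only a limit of the assay and not a number, so the full size of this step stays unknown: the limit of > 30 uM in this assay, at which 1 of the 3 values shown sits.

The compounds shown leave open whether the added aromatic ring alone carries this gain or the double bond is needed too. Going by these compounds, a 2-phenylethyl group at this position would separate the two, and an amine on the new ring remains untested ground here.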